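The source may report more compounds than this note shows. Statements on the series, on what has been measured and on what is new or still open speak of the compounds shown alone.

Compound 1 `CNC(=O)c1cc(C)n(Cc2cc(Cl)ccc2OCc2ccccc2)n1` gives 100 nM in an assay on CHO-K1 cells for displacement of a labelled ligand from prostaglandin E2 receptor EP1 subtype (Homo sapiens); a higher number here means a weaker inhibitor, a lower number a stronger inhibitor. Compound 2 `Cc1cc(C(=O)NCc2ccccn2)nn1Cc1cc(Cl)ccc1OCc1ccccc1` gives 25.1 nM in this assay, and compound 3 `Cc1cc(NC(=O)C(C)C)nn1Cc1cc(Cl)ccc1OCc1ccccc1` gives 25.1 nM. Compound 3 thus stands level with compound 2, the two together holding the lowest numbers of the three, with no change at the digits printed from compound 2 to compound 3 (within the scatter) and a 4.0-fold lower number from compound 1 to compound 3 (0.60 log units; beyond the scatter). Compound 4 `Cc1cc(NC(=O)C2CCCO2)nn1Cc1cc(Cl)ccc1OCc1ccccc1` differs from compound 3 by oxolan-2-yl in place of isopropyl on a carbonyl carbon. Going by the values given here, none of the measured steps touches this carbonyl substituent: a 4.0-fold lower number from compound 1 to compound 2 (0.60 log units; beyond the scatter) and a 4.0-fold lower number from compound 1 to compound 3 (0.60 log units; beyond the scatter) concern other parts of the core, so they give only a sense of scale. Compound 4 is therefore expected to stay close to compound 3, with a 1.4-fold higher number from compound 3 to compound 4 (0.14 log units; within the scatter). The estimate for compound 4 is 35 nM, with a range from 12 nM to 100 nM.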

Compound 4, half-maximal inhibitory concentration: 39.8 nM
Beside the measured number, compound 4's estimate is 1.1-fold (0.06 log units) below it, within the range that was stated.
By their numbers in this assay, from the lowest: compounds 2, 3 and 4 (each within the scatter of the next); then compound 1.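

In this assay, going by these compounds alone, the carbonyl substituent changes for the first time: oxolan-2-yl in place of isopropyl on the carbonyl carbon gives a 1.6-fold higher number from compound 3 to compound 4 (0.20 log units; within the scatter), so this position takes a five-membered ring with one hydrogen-bond acceptor without a step beyond the scatter. The wider comparisons show a 1.6-fold higher number from compound 2 to compound 4 (0.20 log units; within the scatter) and a 2.5-fold lower number from compound 1 to compound 4 (0.40 log units; beyond the scatter), so the new amide stays within the scatter of the pyridinylmethyl amide and retains a modest gain over the methyl amide. No evidence is available to explain this result.

Going by these compounds, whether the ring oxygen contributes at all remains open, and cyclopentyl on the same carbonyl carbon would test this. Also open, on these data alone, is how this position responds to an amine or a carboxylic acid.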